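This account rests on a few compounds, and the source may have more. Where it says the series, first, only, none or still open, it means among the compounds named here.

Three measured compounds share one core and differ only in the cap at the end of the chain. Compound 1 `CC(C)=CCC/C(C)=C/CC1Cc2c(OCCCNS(=O)(=O)c3ccc(Cl)cc3)cc(=O)n(CCCO)c2CC1(C)C` carries a (4-chlorophenyl)sulfonyl on the amine nitrogen; in a functional assay on PANC-1 cells (Homo sapiens) for inhibition, read by MTT assay, with a stated time of 24 h, tested at 10 uM (on this read-out higher numbers stand for more inhibition at the one concentration tested (going by the name of the read-out) and lower numbers for less inhibition), compound 1 gives 16.1%. Compound 2 `CC(C)=CCC/C(C)=C/CC1Cc2c(OCCCNC(=O)c3cccs3)cc(=O)n(CCCO)c2CC1(C)C` has a (thiophen-2-yl)carbonyl there, and in this assay compound 2 gives 11.5%. Compound 3 `CC(C)=CCC/C(C)=C/CC1Cc2c(OCCCNC(=O)c3ccc([N+](=O)[O-])cc3)cc(=O)n(CCCO)c2CC1(C)C` carries a (4-nitrophenyl)carbonyl; in this assay compound 3 gives 6.5%, the lowest of the three numbers, although a number 5 percentage points lower from compound 2 to compound 3 (within the scatter) and a number 9.6 percentage points lower from compound 1 to compound 3 (within the scatter), so none of the three can be set apart from the others. The step of a number 4.6 percentage points lower from compound 1 to compound 2 (within the scatter) is likewise small.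

Compound 4 `COc1ccc(OCCCOc2cc(=O)n(CCCO)c3c2CC(C/C=C(\C)CCC=C(C)C)C(C)(C)C3)cc1` is not yet measured. Relative to compound 3, (4-methoxyphenoxy in place of ((4-nitrophenyl)carbonyl)amino on a saturated chain carbon, three bonds along the chain from an oxygen on an aromatic ring). This change replaces the whole ((4-nitrophenyl)carbonyl)amino cap with 4-methoxyphenoxy rather than exchanging only the group on the amine nitrogen, so none of the three measured steps matches it directly; all they show is that three different caps here gave numbers within the scatter of one another. On that basis the expected step of a number 3.5 percentage points higher from compound 3 to compound 4 (within the scatter) is small, with no direction beyond the scatter. Compound 4 is therefore estimated at 10% in this assay, between 0% and 25%.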

Compound 4, a percentage reported as inhibition, at one concentration (the size of the read-out at that concentration, not a potency): 0%
Estimate against measurement, compound 4: 10 percentage points above; the measured number falls inside the stated range.
By their numbers in this assay, from the lowest: compounds 4, 3, 2 and 1 (each within the scatter of the next, the first and the last beyond it).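

In this assay, for the compounds shown here, the 4-methoxyphenoxy cap is the first change at this saturated chain carbon to separate compounds on this read-out: a number 11.5 percentage points lower from compound 2 to compound 4 (beyond the scatter) and a number 16.1 percentage points lower from compound 1 to compound 4 (beyond the scatter), whereas a number 6.5 percentage points lower from compound 3 to compound 4 (within the scatter) leaves compound 4 indistinguishable from compound 3. The result therefore gives only a partial separation, with compound 4 set apart from the (thiophen-2-yl)carbonyl and (4-chlorophenyl)sulfonyl caps but not from the (4-nitrophenyl)carbonyl cap. Compound 4 is also the only one of the four without the amine nitrogen, yet with compound 3 inseparable from it, the loss of that nitrogen cannot be tied to the lower numbers, and nothing available bears on the reason for these differences.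

The compounds shown leave open whether the ether oxygen, the methoxy group or the whole cap accounts for the separation, which an unsubstituted phenoxy or a 4-methoxyphenyl amide on the same chain would help to settle. They also leave open whether a cap carrying a carboxylic acid or a tertiary amine, or a longer chain before the cap, would give numbers beyond the scatter of all four compounds.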